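The source may hold more compounds than are shown below. What is called first, only, known or untested is meant among the compounds shown, and "the series" means these compounds.

Three compounds share one core and differ only in the group attached to the sulfonyl sulfur. Compound 1 `CNCc1cn(S(=O)(=O)c2ccco2)c(-c2cccnc2F)c1F` carries a furan-2-yl there, and in a functional assay on the whole organism (strain Jcl:Sprague-Dawley) for inhibition, with Rattus norvegicus as the target, with stated times of 3 min and 3 h, at a dose of 1 mg/kg by the intravenous route (on this read-out higher numbers stand for more inhibition at the one dose given (going by the name of the read-out) and lower numbers for less inhibition), compound 1 gives 75%. Compound 2 `CNCc1cn(S(=O)(=O)c2ccccn2)c(-c2cccnc2F)c1F` carries a pyridin-2-yl, and in this assay compound 2 gives 95%. Compound 3 `CNCc1cn(S(=O)(=O)c2ccc(F)cn2)c(-c2cccnc2F)c1F` carries a 5-fluoropyridin-2-yl, and in this assay compound 3 gives 87%. Compound 3 thus stands second highest of the three numbers: a number 12 percentage points higher from compound 1 to compound 3 (beyond the scatter), whereas a number 8 percentage points lower from compound 2 to compound 3 (within the scatter), so compounds 2 and 3 cannot be told apart on this read-out.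

Compound 4 `CNCc1cn(S(=O)(=O)c2cccnc2C)c(-c2cccnc2F)c1F` has not yet been measured. Its change from compound 3 is 2-methylpyridin-3-yl in place of 5-fluoropyridin-2-yl on a sulfonyl sulfur. Among the compounds with values here, two measured steps bear on this, since both also replace the group on the sulfonyl sulfur: a number 20 percentage points higher from compound 1 to compound 2 (beyond the scatter) and a number 12 percentage points higher from compound 1 to compound 3 (beyond the scatter). Both were modest, and the remaining step, a number 8 percentage points lower from compound 2 to compound 3 (within the scatter), stayed within the scatter. Within the data shown here, no measured step tests a 2-methylpyridin-3-yl in this place, so the direction cannot be read from the data; a modest shift either way, or none beyond the scatter, is expected in this assay. Compound 4 is therefore estimated to give 80% in this assay, within a range from 60% to 95%, which is expected to mean a number 7 percentage points lower from compound 3 to compound 4 (within the scatter).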

Compound 4, a percentage reported as inhibition, in the whole organism at one dose (the size of the read-out at that dose, not a potency): 92%
The estimate for compound 4 lay 12 percentage points below the measured number; low and high end bracket the measured number.
By their numbers in this assay, from the lowest: compound 1; then compounds 3, 4 and 2 (each within the scatter of the next).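

Changing the group on the sulfonyl sulfur to 2-methylpyridin-3-yl, which has a methyl group and a different point of attachment, leaves the read-out in this assay unresolved from the two earlier pyridine compounds: a number 5 percentage points higher from compound 3 to compound 4 (within the scatter), and a number 3 percentage points lower from compound 2 to compound 4 (within the scatter). This position therefore accepts more than pyridin-2-yl groups, and compounds 2, 3 and 4 cannot be ranked against one another on this measure. The comparison with the furan-2-yl group gives a number 17 percentage points higher from compound 1 to compound 4 (beyond the scatter), so all three six-membered aromatic rings shown now stand beyond the scatter above compound 1, with no shown compound going against this, though no information is available to explain either result.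

Because each compound was tested at only one dose, these numbers leave open whether compounds 2, 3 and 4 would separate at a lower dose. On these data alone, it also remains open whether this position needs an aromatic ring at all, since an open chain such as propyl or a saturated ring amine such as piperidine would test that directly.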